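Cytotoxicity on Vero cells: trimming the side chain

The source may report more compounds than this note shows. Statements on the series, on what has been measured and on what is new or still open speak of the compounds shown alone.

All three compounds share the core of compound 1 `CCC(=O)Nc1ccc(-c2nc3cc(C(F)(F)F)ccc3[nH]2)cc1` and differ only in the group on the six-membered aromatic ring of carbon only. In an ADME assay on Vero cells (Chlorocebus sabaeus) for cytotoxicity (on this read-out higher numbers stand for lower toxicity in this test and lower numbers for higher toxicity in this test), compound 1 gives no number, only the assay limit > 100000 nM. Compound 2 `CCN(CC)CC(=O)Nc1ccc(-c2nc3cc(C(F)(F)F)ccc3[nH]2)cc1` gives 24000 nM in this assay, the only number shown in the series. The other value, that of compound 1, sits at a limit (the limit of > 100000 nM in this assay, at which 1 of the 2 values shown sits). Going by the values given here, the single measured step is an at least 4.1-fold lower number from compound 1 to compound 2 (0.61 log units; beyond the scatter). Compound 3 `COc1ccc(-c2nc3cc(C(F)(F)F)ccc3[nH]2)cc1` has not yet been measured in this assay and differs from compound 2 by methoxy in place of (((diethylamino)methyl)carbonyl)amino on an aromatic carbon. The measured step bears on this change only in part: it covered the diethylamino alone, whereas here the whole (((diethylamino)methyl)carbonyl)amino leaves and a methoxy enters. Since the diethylamino is among what leaves, a move back toward the side of compound 1, that is a higher number in this assay, is expected, of modest size. Compound 3 is therefore expected to give 60000 nM, within a range from 20000 nM to 200000 nM. The step this estimate means is a 2.5-fold higher number from compound 2 to compound 3 (0.40 log units; beyond the scatter).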

Compound 3, half-maximal cytotoxic concentration: 15000 nM
Compound 3: the middle estimate sits 4.0-fold (0.60 log units) above what was measured, and the stated range ends above it.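

In this assay, replacing the whole (((diethylamino)methyl)carbonyl)amino on this aromatic carbon with methoxy gives a 1.6-fold lower number from compound 2 to compound 3 (0.20 log units; within the scatter), so the two cannot be told apart here. The lower number is therefore not tied to the diethylamino alone, since a methoxy with no amine and no amide reads the same within the scatter, and methoxy in place of propanoylamino gives an at least 6.6-fold lower number from compound 1 to compound 3 (0.82 log units; beyond the scatter), which leaves compound 1 as the one that stands apart on this position. Compound 1 gives only a limit, so this step and the earlier one have a floor but no full size: the limit of > 100000 nM in this assay, at which 1 of the 3 values shown sits.

Going by these compounds, it remains open whether the high limit belongs to the propanoylamino specifically or to simple amides on this aromatic carbon in general, and the values shown give no cause for either step. A free amine or a hydroxy on this carbon, or a longer chain on the carbonyl of the amide, would show whether the lower numbers extend beyond methoxy and the diethylamino side chain.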